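The source may hold more compounds than are shown below. What is called first, only, known or untested is meant among the compounds shown, and "the series" means these compounds.

In a functional assay on MIA PaCa-2 cells (Homo sapiens) for antiproliferative activity, read by MTT assay, with a stated time of 48 h (a higher number here means a weaker inhibitor, a lower number a stronger inhibitor), the three measured compounds stand as follows:

compound 1, `CCCCCc1nc(N)n(CC(=O)Nc2ccc(C)cc2)c1-c1ccccc1Br`, gives 5600 nM;
compound 2, `Cc1ccc(NC(=O)Cn2c(N)nc(CC3CC3)c2-c2ccccc2Br)cc1`, gives 3500 nM;
compound 3, `Cc1ccc(NC(=O)Cn2c(N)nc(CC3CCCCC3)c2-c2ccccc2Br)cc1`, gives 48800 nM.

Compound 3 therefore holds the highest number of the three, beyond the scatter from both others. The two steps that reach it are both sizeable: an 8.7-fold higher number from compound 1 to compound 3 (0.94 log units; beyond the scatter) and a 14-fold higher number from compound 2 to compound 3 (1.14 log units; beyond the scatter), whereas the step between the two smaller groups, a 1.6-fold lower number from compound 1 to compound 2 (0.20 log units; within the scatter), stays within the scatter. Within the data shown here, the group on the saturated chain carbon bound to an aromatic carbon is thus the one place where these compounds move, and the cyclohexyl there is tied to the weakest result.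

Compound 4, `Cc1ccc(Cc2nc(N)n(CC(=O)Nc3ccc(C)cc3)c2-c2ccccc2Br)cc1`, is not yet measured. It differs from compound 3 by 4-methylphenyl in place of cyclohexyl on a saturated chain carbon bound to an aromatic carbon. Among the measured compounds shown here, no measured pair tests an aromatic ring at this position, so the comparison rests only on the fact that every departure from cyclohexyl so far has given a lower number. On that footing a return toward the numbers of compound 1 and compound 2 is expected, though not necessarily all the way, and the step of a 3.3-fold lower number from compound 3 to compound 4 (0.51 log units; beyond the scatter) is the estimated size of it. Compound 4 is accordingly expected to give about 15000 nM in this assay, with a likely range from 3000 nM to 70000 nM.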

Compound 4, half-maximal inhibitory concentration: 2900 nM
Beside the measured number, compound 4's estimate is 5.2-fold (0.71 log units) above it; measured number below the stated range.
By their numbers in this assay, from the lowest: compounds 4, 2 and 1 (each within the scatter of the next); then compound 3.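

In this assay the change from cyclohexyl to 4-methylphenyl gives a 17-fold lower number from compound 3 to compound 4 (1.23 log units; beyond the scatter) and so shows that a six-membered ring at this position does not by itself go with a high number: the aromatic ring, although it holds more heavy atoms than the cyclohexyl it replaces, does not share that ring's result. The earlier compounds shown here could be read as showing that a larger group here raises the number, but compound 4 goes against that reading, with a 1.2-fold lower number from compound 2 to compound 4 (0.08 log units; within the scatter) and a 1.9-fold lower number from compound 1 to compound 4 (0.29 log units; within the scatter) both lying within the scatter, so that among the four compounds only compound 3, with its cyclohexyl, stands apart. Nothing available explains why the two six-membered rings part so sharply.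

The compounds shown leave open what a plain phenyl would give on the same saturated chain carbon, and so whether the methyl of the 4-methylphenyl plays any part in this result. They also leave open whether a piperidine ring, or a cyclopentyl ring, would stay with compound 4 or move toward compound 3.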